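Swapping the ketone chain for a small amide

This account rests on a few compounds, and the source may have more. Where it says the series, first, only, none or still open, it means among the compounds named here.

Measured so far:
compound 1, `COc1ccc2c(c1)OC(c1cc(OC)c(OC)c(OC)c1)C(C(=O)Nc1ccccc1)=C2`, 17500 nM
compound 2, `CCCC(=O)C1=Cc2ccc(OC)cc2OC1c1cc(OC)c(OC)c(OC)c1`, 11700 nM
compound 3, `CCOC(=O)C1=Cc2ccc(OC)cc2OC1c1cc(OC)c(OC)c(OC)c1`, 25000 nM

All three compounds share a core and were tested in a functional assay for inhibition of nuclear factor NF-kappa-B complex (Homo sapiens); on this read-out higher numbers stand for weaker inhibition and lower numbers for stronger inhibition. Among them, compound 2 gives the lowest number; its nearest neighbour is compound 1, whose value differs by a 1.5-fold lower number from compound 1 to compound 2 (0.17 log units; within the scatter), and the farthest is compound 3, reached by a 2.1-fold higher number from compound 2 to compound 3 (0.33 log units; beyond the scatter).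

Compound 4, `COc1ccc2c(c1)OC(c1cc(OC)c(OC)c(OC)c1)C(C(=O)N(C)C)=C2`, has not yet been measured. It differs from compound 2 in one place: dimethylamino in place of propyl on a carbonyl carbon.

Among the measured compounds shown here, two measured steps bear on this change, both altering the same carbonyl carbon. The step from the anilino amide to the propyl ketone, a 1.5-fold lower number from compound 1 to compound 2 (0.17 log units; within the scatter), stays within the scatter, while the step to the ethoxy ester, a 2.1-fold higher number from compound 2 to compound 3 (0.33 log units; beyond the scatter), is a modest rise. Since compound 4 is again an amide, a result near compound 1 seems most likely. Compound 4 is therefore expected to give about 17000 nM, between 8500 nM and 34000 nM, a step of a 1.5-fold higher number from compound 2 to compound 4 (0.16 log units; within the scatter) that is expected to fall within the scatter.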

Compound 4, half-maximal inhibitory concentration: > 50000 nM
Compound 4: no number, only a limit; the forecaster's own chance of this, stated with the estimate: 10%; at least 2.9-fold (0.46 log units) between middle value and limit.
By their numbers in this assay, from the lowest: compounds 2, 1 and 3 (each within the scatter of the next, the first and the last beyond it). At a limit, above all of these: compound 4.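

In this assay compound 4 gives no number, only a limit: (the limit of > 50000 nM in this assay, at which 1 of the 4 values shown sits). The earlier compounds had shown only small shifts on this carbonyl carbon, but dimethylamino separates clearly from both propyl (an at least 4.2-fold higher number from compound 2 to compound 4 (0.63 log units; beyond the scatter)) and anilino (an at least 2.8-fold higher number from compound 1 to compound 4 (0.45 log units; beyond the scatter)), so the amide link alone does not keep a compound near compound 1. Against the ester the separation is less firm, since the floor of the step lies within the scatter (an at least 2.0-fold higher number from compound 3 to compound 4 (0.30 log units; that floor lies within the scatter)).

Going by these compounds, how far compound 4 truly lies beyond these floors stays open, since only a limit is available. Also open, on these data alone, is where a methylamino group, an unsubstituted amino group or a longer ketone chain on this carbonyl carbon would fall relative to compound 2 and compound 4.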